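A few compounds are considered here, and "the series" means these few. Any claim that something is new, unique, unknown or untested is made for them only; others in the source may bear on it.

Working notes on the series.

Compound 1 `Cn1ccc2c(Oc3ccc(NC(=O)c4cc5cccnc5n(-c5ccc(F)cc5)c4=O)cc3F)ccnc21` in a functional assay on NCI-H460 cells (Homo sapiens) for antiproliferative activity, read by MTT assay, with a stated time of 72 h (a higher number here means a weaker inhibitor, a lower number a stronger inhibitor), gives 250 nM. Among the measured compounds shown here, compound 2 `Cn1ccc2c(Oc3ccc(NC(=O)c4cc5cccnc5n(-c5ccc(Br)cc5)c4=O)cc3F)ccnc21` in this assay gives 420 nM; the step of a 1.7-fold higher number from compound 1 to compound 2 (0.23 log units; within the scatter) is the only measured step in the set and lies within the scatter. Going by these compounds, compound 3 `Cn1ccc2c(Oc3ccc(NC(=O)c4cc5cccnc5n(-c5ccc(F)c(Cl)c5)c4=O)cc3F)ccnc21` carries a 3-chloro-4-fluorophenyl on the aromatic nitrogen of the shared core, but in this assay compound 3 gives "not determined" (no result reported), that is, no result is reported for it, so compound 3 stands without a number and its position relative to compound 1 and compound 2 is unknown.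

Compound 4 `Cn1ccc2c(Oc3ccc(NC(=O)c4cc5cccnc5n(-c5ccc(C(F)(F)F)cc5Cl)c4=O)cc3F)ccnc21` differs from compound 3 by 2-chloro-4-(trifluoromethyl)phenyl in place of 3-chloro-4-fluorophenyl on an aromatic nitrogen. For the measured compounds named here, no measured step covers this change. Going by the values given here, the one step on record, a halogen swap on the same aryl ring, was within the scatter, which suggests that the aryl ring attached to the aromatic nitrogen tolerates variation, but the new ring also brings a group of 1 heavy atom ortho to the fused ring, for which there is no precedent here. Compound 4 is therefore expected to lie near the measured compounds in this assay, estimated at 450 nM with a range of 120 nM to 1800 nM.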

Compound 4, half-maximal inhibitory concentration: 6010 nM
Estimate against measurement, compound 4: 13-fold (1.13 log units) below, and the stated range ends below it.
By their numbers in this assay, from the lowest: compounds 1 and 2 (each within the scatter of the next); then compound 4.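

The aryl group on the aromatic nitrogen does not tolerate every change in this assay. The halogen swap stayed within the scatter, but 2-chloro-4-(trifluoromethyl)phenyl in place of 4-bromophenyl gives a 14-fold higher number from compound 2 to compound 4 (1.16 log units; beyond the scatter), and the same group in place of 4-fluorophenyl gives a 24-fold higher number from compound 1 to compound 4 (1.38 log units; beyond the scatter), so this position can matter a great deal to the antiproliferative read-out. Nothing on hand accounts for the loss of activity.

The entering group carries both a chloro and a trifluoromethyl group, and the compounds shown do not separate their shares in these steps, while compound 3 has no number to place its 3-chloro-4-fluorophenyl group. Going by these compounds, how a methoxy group or an amine on this aryl ring would read also remains open.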